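The source may hold more compounds than are shown below. What is called first, only, known or untested is meant among the compounds shown, and "the series" means these compounds.

Measured so far:
- compound 1, `CC(c1c(F)cc2ncccc2c1F)n1cnc2ncc(-c3cnn(C)c3)nc21`: 11 uL/min in an ADME assay on microsomes from liver (Homo sapiens) for metabolic stability, read by LC-MS, using NADPH, with stated times of 5 min and 30 min, tested at 1 uM; a lower number here means slower removal, a higher number faster removal of the compound
- compound 2, `CC(c1c(F)cc2ncccc2c1F)n1cnc2ncc(-c3ccncc3)nc21`: 14 uL/min in this assay
- compound 3, `CNC(=O)c1ccc(-c2cnc3ncn(C(C)c4cc5cccnc5cc4F)c3n2)cc1F`: 16 uL/min in this assay

On these numbers compound 2 sits within the scatter of both compound 1 and compound 3; the three values are not distinguishable from one another. For the measured compounds named here, the one step that has been measured at the same aromatic carbon, a 1.3-fold higher number from compound 1 to compound 2 (0.10 log units; within the scatter), stays within the scatter.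

Compound 4, `CC(c1c(F)cc2ncccc2c1F)n1cnc2ncc(-c3cnc4ccccc4c3)nc21`, differs from compound 2 by quinolin-3-yl in place of pyridin-4-yl on an aromatic carbon. Going by the values given here, the only step bearing on this change is the one from compound 1 to compound 2, and it was flat. Among the compounds with values here, no measured step covers an aryl group of the size of quinolin-3-yl, so the expectation rests on that single flat step. For compound 4 the expected step is a 1.2-fold higher number from compound 2 to compound 4 (0.08 log units; within the scatter), without a clear direction beyond the scatter. Compound 4 is estimated at 17 uL/min, with a range from 8 uL/min to 36 uL/min in this assay.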

Compound 4, intrinsic clearance in a liver preparation (reported as CLH), per the amount of preparation that the assay uses: 51 uL/min
The estimate for compound 4 lay 3.0-fold (0.48 log units) below the measured number; the whole stated range lies below it.
By their numbers in this assay, from the lowest: compounds 1, 2 and 3 (each within the scatter of the next); then compound 4.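

In this assay this aromatic carbon proves sensitive to the group it carries, with a 3.6-fold higher number from compound 2 to compound 4 (0.56 log units; beyond the scatter) and a 4.6-fold higher number from compound 1 to compound 4 (0.67 log units; beyond the scatter) for quinolin-3-yl. For the compounds shown here, both steps lie beyond the scatter, so the flat exchange between the groups of the earlier compounds does not extend to quinolin-3-yl. No measured finding on these compounds accounts for the rise.

Open, as far as these compounds go, is whether the step follows the added six-membered aromatic ring of carbon only or the way quinolin-3-yl is attached. Also open, from the compounds shown here alone, is how a plain phenyl, or a quinolin-3-yl carrying an amine or a carboxylic acid, would stand at this carbon.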